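A few compounds are considered here, and "the series" means these few. Any claim that something is new, unique, unknown or untested is made for them only; others in the source may bear on it.

Measured in a functional assay, read by spectrophotometry, in phosphate buffer, with a stated time of 10 min, at pH 6.6; on this read-out higher numbers stand for an effect only at larger amounts of compound and lower numbers for an effect already at smaller amounts:
- compound 1 `COC(=O)C1=C(C)NC(=O)NC1c1ccc(O)cc1`: 67 ug/mL
- compound 2 `CCOC(=O)C1=C(C)NC(=O)NC1c1ccc([N+](=O)[O-])cc1`: 238 ug/mL

Of these two, compound 2 carries the higher number, and the gap to compound 1 lies beyond the scatter. Compound 3 `CCOC(=O)C1=C(C)NC(=O)NC1c1ccc(O)cc1` departs from compound 2 in one place: hydroxy in place of nitro on an aromatic carbon, para to a large group (hydroxy in place of nitro on an aromatic carbon). Among the measured compounds shown here, no step between measured compounds isolates this change. For the measured compounds named here, the only guide is compound 1, which also carries the hydroxy and gives 67 ug/mL, against 238 ug/mL for compound 2. These two differ in more than this one place, so the guide is weak. A step toward lower numbers in this assay is expected, probably somewhat smaller than the gap between them but still beyond the scatter. The estimated step is a 2.5-fold lower number from compound 2 to compound 3 (0.40 log units; beyond the scatter). For compound 3 the expected value is 95 ug/mL, with an estimated range of 35 ug/mL to 240 ug/mL.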

Compound 3, half-maximal effective concentration: 61.4 ug/mL
Beside the measured number, compound 3's estimate is 1.5-fold (0.19 log units) above it; low and high end bracket the measured number.
By their numbers in this assay, from the lowest: compounds 3 and 1 (each within the scatter of the next); then compound 2.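

In this assay, hydroxy in place of nitro on an aromatic carbon, para to a large group, can now be read as a single change: it gives a 3.9-fold lower number from compound 2 to compound 3 (0.59 log units; beyond the scatter) and so shows that this position responds to the exchange. With the hydroxy held in place, methyl in place of hydrogen on a saturated chain carbon bound to an oxygen next to a carbonyl group gives a 1.1-fold lower number from compound 1 to compound 3 (0.04 log units; within the scatter) and does not separate the two compounds on this read-out. No measurement at hand accounts for the step at the aromatic carbon.

On these data alone, it remains open whether an amine or a methoxy group on the same aromatic carbon would read like hydroxy or like nitro. Also open, as far as these compounds go, is whether a longer chain in place of that methyl would still leave the number within the scatter, with either hydroxy or nitro on the aromatic carbon.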